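Extending the Group on the Aromatic Nitrogen

This account rests on a few compounds, and the source may have more. Where it says the series, first, only, none or still open, it means among the compounds named here.

Compound 1 `C/C(=C\C(=O)Nc1ccccc1OCCCC(=O)O)c1ccc2c(ccn2C)c1` and compound 2 `CCCn1ccc2cc(/C(C)=C/C(=O)Nc3ccccc3OCCCC(=O)O)ccc21` share one core and differ only at a saturated chain carbon bound to an aromatic nitrogen. In an assay on Prostate gland for inhibition of steroid 5-alpha-reductase (Rattus norvegicus) (on this read-out higher numbers stand for weaker inhibition and lower numbers for stronger inhibition), compound 1 gives 780 nM, while compound 2 gives 190 nM. Within the data shown here, the one measured step, a 4.1-fold lower number from compound 1 to compound 2 (0.61 log units; beyond the scatter), accompanies ethyl in place of hydrogen at that carbon. Among the measured compounds shown here, compound 2 therefore stands at the lower of the two numbers, with compound 1 as its only neighbour.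

Compound 3 `CCCCc1ccc(Cn2ccc3cc(/C(C)=C/C(=O)Nc4ccccc4OCCCC(=O)O)ccc32)cc1` has not yet been measured. Its change from compound 2 is 4-butylphenyl in place of ethyl on a saturated chain carbon bound to an aromatic nitrogen. For the measured compounds named here, the only step known here sits at the same carbon and was a modest gain beyond the scatter, so a further enlargement there is taken as a hint, not a rule, that the number may fall again. With a single step to lean on, the range is kept wide. Compound 3 is expected to give about 90 nM, between 20 nM and 400 nM, an estimated 2.1-fold lower number from compound 2 to compound 3 (0.32 log units; beyond the scatter).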

Compound 3, half-maximal inhibitory concentration: 100 nM
Beside the measured number, compound 3's estimate is 1.1-fold (0.05 log units) below it; the range from low to high includes it.
By their numbers in this assay, from the lowest: compounds 3 and 2 (each within the scatter of the next); then compound 1.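

In this assay the much larger group at the saturated chain carbon bound to an aromatic nitrogen gives a 1.9-fold lower number from compound 2 to compound 3 (0.28 log units; within the scatter) and so does not separate the two compounds, even though 4-butylphenyl brings 10 heavy atoms and a six-membered aromatic ring where ethyl has 2 heavy atoms and no ring. Measured against hydrogen at that carbon, the same group gives a 7.8-fold lower number from compound 1 to compound 3 (0.89 log units; beyond the scatter) and thus keeps the gain seen with ethyl, showing that this position accepts an aromatic ring and a far larger group with no return toward the number of compound 1. Nothing at hand explains these numbers.

From the compounds shown here alone, it remains open whether a carboxylic acid or an amine in place of the butyl on the 4-butylphenyl group would keep the number of compound 3 in this range. Also open, going by these compounds, is whether a simple longer chain such as hexyl at the same carbon would match the aromatic group, or whether a benzyl group without butyl would do so.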